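Replacing an Isopentyl Chain with a Methoxyphenoxy Ring

This account rests on a few compounds, and the source may have more. Where it says the series, first, only, none or still open, it means among the compounds named here.

Compound 3 `COc1ccc(F)cc1CNCCCNc1ccnc2cc(CCC(C)C)ccc12` gives 4200 nM in a physicochemical assay for solubility, with a stated time of 18 h, at pH 7.4 (on this read-out lower numbers stand for lower solubility and higher numbers for higher solubility), level with compound 2 `COc1ccc(F)cc1CNCCCNc1ccnc2cc(Cc3cc(C)cc(C)c3)ccc12` at 4200 nM. Compound 1 `COc1ccc(Oc2ccc3c(NCCCNCc4cc(F)ccc4OC)ccnc3c2)cc1` gives 14500 nM. Compound 4 `COc1cccc(Oc2ccc3c(NCCCNCc4cc(F)ccc4OC)ccnc3c2)c1` differs from compound 3 by 3-methoxyphenoxy in place of isopentyl on an aromatic carbon. The step that bears on this runs the other way: a 3.5-fold lower number from compound 1 to compound 3 (0.54 log units; beyond the scatter), and likewise a 3.5-fold lower number from compound 1 to compound 2 (0.54 log units; beyond the scatter), while no change at the digits printed from compound 2 to compound 3 (within the scatter). Compound 1 carries a 4-methoxyphenoxy group where compound 4 carries a 3-methoxyphenoxy group, so returning a methoxyphenoxy ring in place of isopentyl is expected to raise solubility, by roughly a 3.3-fold higher number from compound 3 to compound 4 (0.52 log units; beyond the scatter). Compound 4 is therefore estimated at 14000 nM, with a range from 6500 nM to 30000 nM.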

Compound 4, solubility: 14500 nM
Beside the measured number, compound 4's estimate is 1.0-fold (0.02 log units) below it; the measured number falls inside the stated range.
By their numbers in this assay, from the lowest: compounds 2 and 3 (each within the scatter of the next); then compounds 1 and 4 (each within the scatter of the next).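

In this assay putting 3-methoxyphenoxy in place of 4-methoxyphenoxy gives no change at the digits printed from compound 1 to compound 4 (within the scatter) so the two ring patterns cannot be told apart on this read-out. The 3-methoxyphenoxy group also stands clear of the other two groups at this aromatic carbon, with a 3.5-fold higher number from compound 3 to compound 4 (0.54 log units; beyond the scatter) against isopentyl and a 3.5-fold higher number from compound 2 to compound 4 (0.54 log units; beyond the scatter) against 3,5-dimethylbenzyl. No measured evidence is available to explain these steps.

On these data alone, it remains open whether the higher number depends on the methoxy group, and what an unsubstituted phenoxy, an amine or a carboxylic acid would give at this carbon.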